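The source may report more compounds than this note shows. Statements on the series, on what has been measured and on what is new or still open speak of the compounds shown alone.

Measured compounds:
compound 1 `Cc1ccc(OCC(=O)N(Cc2cccs2)C(C)(C)C)cc1`: 11000 nM
compound 2 `CCN(Cc1cccs1)C(=O)COc1ccc2c(c1)COC2`: 61 nM

In an assay on HEK293 cells for agonist activity at transient receptor potential cation channel subfamily M member 8 (Homo sapiens), read by fluorescence and calcium flux, with a stated time of 15 min (on this read-out higher numbers stand for an effect only at larger amounts of compound and lower numbers for an effect already at smaller amounts), compound 1 gives 11000 nM, the highest of the two numbers, with compound 2 at 61 nM, a gap beyond the scatter. Compound 3 `Cc1ccc(OCC(=O)N(Cc2cccs2)c2cn[nH]c2)cc1` is not yet measured. It differs from compound 1 by 1H-pyrazol-4-yl in place of tert-butyl on an amide-type nitrogen. Among the compounds with values here, no step between measured compounds covers this change, so its size is uncertain; a moderate move toward lower numbers is expected, though a change either way beyond the scatter would not surprise. For compound 3 the expected step is a 3.7-fold lower number from compound 1 to compound 3 (0.56 log units; beyond the scatter). Compound 3 is thus estimated at 3000 nM, between 500 nM and 20000 nM.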

Compound 3, half-maximal effective concentration: 1.4 nM
Estimate against measurement, compound 3: 2100-fold (3.33 log units) above; measured number below the stated range.
By their numbers in this assay, from the lowest: compound 3; then compound 2; then compound 1.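

In this assay, within the data shown here, the amide-type nitrogen proves a highly sensitive position: 1H-pyrazol-4-yl in place of tert-butyl gives a 7900-fold lower number from compound 1 to compound 3 (3.90 log units; beyond the scatter) in a single change, which the earlier compounds could not show. The step replaces a group with no ring by a five-membered aromatic ring carrying 1 hydrogen-bond donor and 1 hydrogen-bond acceptor. No supporting evidence bears on the reason for its size. The compounds shown do not separate the contribution of the ring from that of its nitrogen atoms. As far as these compounds go, how a phenyl or cyclopentyl group on this nitrogen would read remains open.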